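A few compounds are considered here, and "the series" means these few. Any claim that something is new, unique, unknown or untested is made for them only; others in the source may bear on it.

Series notes. Compound 1 is `CCCCCCCCCCCCCCCCCCOCC(CCC1CO1)NC(C)=O` and compound 2 is `CCCCCCCCCCCCCCCCCCOCC(CCCO)NC(C)=O`. In an assay for inhibition of putative inactive group IIC secretory phospholipase A2 (Homo sapiens) (a higher number here means a weaker inhibitor, a lower number a stronger inhibitor), compound 1 gives only a limit, > 200000 nM. In this assay compound 2 likewise gives only a limit, > 200000 nM. Among the compounds with values here, the only measured step is a step that the two limits leave unreadable from compound 1 to compound 2, and its size cannot be read. Compound 2 thus stands at the limit with no number of its own, and both values shown sit on (the limit of > 200000 nM in this assay, at which 2 of the 2 values shown sit).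

The next compound is compound 3, `CCCCCCCCCCCCCCCCCCOCC(CCC(C)=O)NC(C)=O`. Its difference from compound 2 is acetyl in place of hydroxymethyl on a saturated chain carbon, three bonds along the chain from an amide-type nitrogen. Within the data shown here, no measured step gives a readable size or direction for a change at this position, so nothing in the data fixes the direction of the change in this assay. With both measured compounds sitting at the limit, the expectation is that compound 3 also lands at or beyond the limit, and the step that the limit leaves unreadable from compound 2 to compound 3 is expected to be small or unreadable. Compound 3 is estimated at 300000 nM, with an expected range from 100000 nM to 1000000 nM.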

Compound 3, half-maximal inhibitory concentration: > 200000 nM
Compound 3 gave a limit, no number; the forecaster's own chance of this, stated with the estimate: 85%; the middle value does not contradict the limit.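

In this assay compound 3 gives only a limit, > 200000 nM, so neither its step from compound 1 nor its step from compound 2 can be read. The compounds shown leave open whether any group at this place, on a saturated chain carbon, three bonds along the chain from an amide-type nitrogen, gives a measurable value: the limit of > 200000 nM in this assay, at which 3 of the 3 values shown sit.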